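Adding fluoro to the iodo compound 2

The source may hold more compounds than are shown below. What is called first, only, known or untested is meant among the compounds shown, and "the series" means these compounds.

In a functional assay on K562 cells (Homo sapiens) for antiproliferative activity, read by MTT assay, with a stated time of 24 h (a lower number here means a stronger inhibitor, a higher number a weaker inhibitor), compound 1 `COC(=O)c1scc(-c2ccc(NC(=O)c3cccc(C(F)(F)F)c3)cc2)c1OC` gives 6130 nM and compound 2 `COC(=O)c1scc(-c2ccc(NC(=O)c3cccc(I)c3)cc2)c1OC` gives 14700 nM on the shared core. Within the data shown here, compound 2 therefore holds the higher of only two numbers, and a lower number would mean a gain. Among the measured compounds shown here, the one measured step is a 2.4-fold higher number from compound 1 to compound 2 (0.38 log units; beyond the scatter), with iodo in place of trifluoromethyl on an aromatic carbon.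

Compound 3 `COC(=O)c1scc(-c2ccc(NC(=O)c3cc(I)ccc3F)cc2)c1OC` keeps the iodo group and differs from compound 2 by fluoro in place of hydrogen on an aromatic carbon, ortho to a large group and para to the iodo group. For the measured compounds named here, no measured step adds fluoro, so the single step available bears on this change only loosely. That step, a 2.4-fold higher number from compound 1 to compound 2 (0.38 log units; beyond the scatter), offers a modest scale and no direction. No clear shift is therefore expected, and the estimated change is a 1.1-fold lower number from compound 2 to compound 3 (0.05 log units; within the scatter), which is expected to stay within the scatter. For compound 3 the estimated value in this assay is 13000 nM, with an expected range from 5500 nM to 30000 nM.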

Compound 3, half-maximal inhibitory concentration: 35600 nM
For compound 3 the middle estimate is 2.7-fold (0.44 log units) below the measured one; the whole stated range lies below it.
By their numbers in this assay, from the lowest: compound 1; then compound 2; then compound 3.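

In this assay, among these compounds, fluoro in place of hydrogen on an aromatic carbon, ortho to a large group and para to an iodo group, is not a neutral change: the step is a 2.4-fold higher number from compound 2 to compound 3 (0.38 log units; beyond the scatter) and gives the first reading at this position, in the direction of weaker inhibition. Relative to the trifluoromethyl compound, 2-fluoro-5-iodophenyl in place of 3-(trifluoromethyl)phenyl gives a 5.8-fold higher number from compound 1 to compound 3 (0.76 log units; beyond the scatter) and leaves compound 3 with the highest number of the three, so both changes made to this ring so far have raised the number. No measurement at hand accounts for the rise, and it stands here as an observation only.

The compounds shown leave open whether the rise belongs to fluoro itself or would also follow a chloro, methyl or amine group at the same position, and whether it would carry over to a ring bearing trifluoromethyl rather than iodo. Also open, going by these compounds, is whether any group on this ring, such as a nitrile or a carboxylic acid, would bring the number below that of compound 1 at 6130 nM in this assay.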